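The source may report more compounds than this note shows. Statements on the series, on what has been measured and on what is new or still open speak of the compounds shown alone.

Measured so far in a functional assay on RT-112 cells (Homo sapiens) for antiproliferative activity, read by MTT assay, with a stated time of 72 h; a higher number here means a weaker inhibitor of growth, a lower number a stronger inhibitor of growth:
- compound 1 `COc1cc(Nc2ncnc3c(NC(=O)Nc4cc(C)cc(C)c4)cccc23)cc(OC)c1`: 10100 nM
- compound 2 `COc1cc(Nc2ncnc3c(NC(=O)Nc4ccc(Cl)cc4)cccc23)cc(OC)c1`: 2490 nM
- compound 3 `COc1cc(Nc2ncnc3c(NC(=O)Nc4ccc(C(F)(F)F)cc4Cl)cccc23)cc(OC)c1`: 1080 nM

Compound 3 gives the lowest number of the three, at 1080 nM. The series shows a 2.3-fold lower number from compound 2 to compound 3 (0.36 log units; beyond the scatter) and a 9.4-fold lower number from compound 1 to compound 3 (0.97 log units; beyond the scatter), both modest but beyond the scatter.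

Next is compound 4 `CCOC(=O)c1ccc(NC(=O)Nc2cccc3c(Nc4cc(OC)cc(OC)c4)ncnc23)cc1`, which keeps the shared core and changes only the group on the amide-type nitrogen: 4-(ethoxycarbonyl)phenyl in place of 2-chloro-4-(trifluoromethyl)phenyl on an amide-type nitrogen.

All three measured steps are changes at this same place, the third being a 4.1-fold lower number from compound 1 to compound 2 (0.61 log units; beyond the scatter). Among the measured compounds shown here, none of the measured compounds carries the 4-(ethoxycarbonyl)phenyl group, so no step speaks to it directly. For the measured compounds named here, compound 2, the only measured compound with a single group named at 4 on this ring, gives 2490 nM, and that value is the closest guide.

A modest move to a higher number is expected, estimated as a 2.3-fold higher number from compound 3 to compound 4 (0.36 log units; beyond the scatter). Compound 4 is estimated at 2500 nM, with an expected range of 800 nM to 8000 nM.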

Compound 4, concentration for 50% growth inhibition: 317 nM
Estimate against measurement, compound 4: 7.9-fold (0.90 log units) above; the measured number lies below the stated range.
By their numbers in this assay, from the lowest: compound 4; then compound 3; then compound 2; then compound 1.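

In this assay, 4-(ethoxycarbonyl)phenyl on the amide-type nitrogen goes past the best earlier group, 2-chloro-4-(trifluoromethyl)phenyl, with a 3.4-fold lower number from compound 3 to compound 4 (0.53 log units; beyond the scatter) and leaves compound 4 with the lowest number of the four, its steps to all the others being beyond the scatter. Ethoxycarbonyl in place of chloro on an aromatic carbon gives a 7.9-fold lower number from compound 2 to compound 4 (0.90 log units; beyond the scatter) and so shows that this one group can carry the series well beyond what chloro gave, while the full span at this position now reaches a 32-fold lower number from compound 1 to compound 4 (1.50 log units; beyond the scatter) and is the only step of the series printed as large. No measurement available here accounts for these steps.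

As far as these compounds go, whether the lower number depends on the intact ester remains open. A carboxylic acid, a primary amide or a longer ester chain in place of ethoxycarbonyl would test that.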